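A few compounds are considered here, and "the series" means these few. Any claim that something is new, unique, unknown or untested is made for them only; others in the source may bear on it.

In a functional assay on V79 cells (Cricetulus griseus) for cytotoxicity, read by colony formation (on this read-out higher numbers stand for weaker inhibition and lower numbers for stronger inhibition), compound 1 (`CC1(CN)CCN(c2cc3c(cc2F)c(=O)c(C(=O)O)cn3C2CC2)C1`) gives 23 ug/mL, compound 2 (`CC1(CN)CCN(c2c(F)cc3c(=O)c(C(=O)O)cn(C4CC4)c3c2Cl)C1`) gives 8 ug/mL and compound 3 (`COc1c(N2CCC(C)(CN)C2)c(F)cc2c(=O)c(C(=O)O)cn(C3CC3)c12`) gives 38 ug/mL. Chloro in place of hydrogen on an aromatic carbon gives a 2.9-fold lower number from compound 1 to compound 2 (0.46 log units; beyond the scatter), so compound 1 reads clearly higher than compound 2. Methoxy in place of hydrogen gives a 1.7-fold higher number from compound 1 to compound 3 (0.22 log units; within the scatter), which separates compound 1 from compound 3 by no real margin. Compound 4 (`NC1CCCN(c2cc3c(cc2F)c(=O)c(C(=O)O)cn3C2CC2)C1`) changes a different group: 3-aminopiperidin-1-yl in place of 3-(aminomethyl)-3-methylpyrrolidin-1-yl on an aromatic carbon. Going by the values given here, no measured step touches this group. The largest, a 4.8-fold higher number from compound 2 to compound 3 (0.68 log units; beyond the scatter), shows only how far these numbers can move, so no step beyond the scatter is expected in this assay. The expected change is a 1.2-fold lower number from compound 1 to compound 4 (0.06 log units; within the scatter). Compound 4 is estimated at 20 ug/mL, with an expected range of 7 ug/mL to 60 ug/mL.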

Compound 4, half-maximal inhibitory concentration: > 500 ug/mL
Compound 4: a limit, no number; the forecaster's own chance of this, stated with the estimate: 8%; middle value at least 25-fold (1.39 log units) from the limit.
By their numbers in this assay, from the lowest: compound 2; then compounds 1 and 3 (each within the scatter of the next). At a limit, above all of these: compound 4.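

In this assay, putting 3-aminopiperidin-1-yl in place of 3-(aminomethyl)-3-methylpyrrolidin-1-yl gives an at least 21-fold higher number from compound 1 to compound 4 (1.33 log units; beyond the scatter). Going by these compounds alone, the group on this aromatic carbon, ortho to a fluoro group, can therefore move this read-out further than any step among the earlier compounds. The result for compound 4 is a limit, not a number: the limit of > 500 ug/mL in this assay, at which 1 of the 4 values shown sits.

This one change alters the ring and its substituents together, leaving their separate contributions open. A 3-aminopyrrolidin-1-yl group here would separate the six-membered ring from the loss of the methyl and the shorter amine chain.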